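Cutting back the long chain of compound 1

A few compounds are considered here, and "the series" means these few. Any claim that something is new, unique, unknown or untested is made for them only; others in the source may bear on it.

In a functional assay on Bel-7402 cells (Homo sapiens) for inhibition, read by MTT assay, with a stated time of 72 h (on this read-out higher numbers stand for weaker inhibition and lower numbers for stronger inhibition), compound 1 `Nc1nc2cc(-c3nn(CCCCCCCCCC(=O)NO)c4ncnc(N)c34)ccc2o1` gives > 50000 nM, which is a limit of the assay and not a number. Compound 1 therefore stands at the limit of > 50000 nM in this assay, at which 1 of the 2 values shown sits. Compound 2 `Nc1ncnc2c1c(-c1cnc3[nH]ccc3c1)nn2CCCCCCCCCC(=O)NO` has the same chain with a different aromatic group, and it gives 42100 nM. The measured step between them is an at least 1.1-fold lower number from compound 1 to compound 2 (0.07 log units; that floor lies within the scatter).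

Compound 3 `Nc1nc2cc(-c3nn(CCCCC(=O)NO)c4ncnc(N)c34)ccc2o1` keeps the core of compound 1 but has a much shorter chain: hydroxycarbamoyl in place of 5-(hydroxycarbamoyl)pentyl on a saturated chain carbon, four bonds along the chain from an aromatic nitrogen. Here hydroxycarbamoyl stands in place of 5-(hydroxycarbamoyl)pentyl on a saturated chain carbon, four bonds along the chain from an aromatic nitrogen.

Going by the values given here, the only measured step leaves the chain untouched, so no measurement shows what chain length does here. With compound 1 at > 50000 nM, any number that appears is expected to be lower, so the forecast is loose. The estimated change is an at least 2.0-fold lower number from compound 1 to compound 3 (0.30 log units; that floor lies within the scatter), and another limit reading remains quite possible. For compound 3 the expected value is 25000 nM, with an estimated range from 6000 nM to 50000 nM.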

Compound 3, half-maximal inhibitory concentration: 2400 nM
Compound 3: the middle estimate sits 10-fold (1.02 log units) above what was measured, outside the stated range (below it).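

Going by these compounds alone, the earlier step changed only the aromatic group and left the chain alone, so this is the first sign that the chain itself can move the read-out. In this assay, the shorter chain, with hydroxycarbamoyl in place of 5-(hydroxycarbamoyl)pentyl on a saturated chain carbon, four bonds along the chain from an aromatic nitrogen, gives an at least 20-fold lower number from compound 1 to compound 3 (1.31 log units; beyond the scatter). Compound 1 is held at a limit and not at a number, so this step is only a floor and the true gap may be wider: the limit of > 50000 nM in this assay, at which 1 of the 3 values shown sits.

Only two chain lengths on this core are shown, so it stays open whether the read-out changes steadily between them, whether some intermediate length does better than either, and whether a still shorter chain would go further. Also open, going by these compounds, are whether a carboxylic acid or a primary amide could replace the hydroxycarbamoyl at the chain end, and whether the shorter chain would bring a similar drop when paired with the aromatic group of compound 2.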